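Cyclopentyl to Benzyl on a Shared Core

A few compounds are considered here, and "the series" means these few. Any claim that something is new, unique, unknown or untested is made for them only; others in the source may bear on it.

Of the compounds shown here, three sharing one core have been tested in a functional assay on MCF7 cells (Homo sapiens) for cytotoxicity, read by WST assay, with a stated time of 72 h; on this read-out higher numbers stand for weaker inhibition and lower numbers for stronger inhibition. Compound 1 (`O=C1Nc2c(ccc(F)c2F)C1(c1ccc(O)cc1)c1cccs1`), which carries thiophen-2-yl, gives 82 nM. Compound 2 (`O=C1Nc2c(ccc(F)c2F)C1(c1ccncc1)c1ccc(O)cc1`), which carries pyridin-4-yl, gives 37 nM. Compound 3 (`O=C1Nc2c(ccc(F)c2F)C1(c1ccc(O)cc1)C1CCCC1`), which carries cyclopentyl, gives 12 nM, the lowest of the three numbers and so the strongest inhibition in this small set. The next structure, compound 4 (`O=C1Nc2c(ccc(F)c2F)C1(Cc1ccccc1)c1ccc(O)cc1`), has benzyl in place of cyclopentyl on a saturated ring carbon.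

For the measured compounds named here, two measured steps bear on this change, since both end at cyclopentyl in that same place. They are a 6.8-fold lower number from compound 1 to compound 3 (0.83 log units; beyond the scatter) and a 3.1-fold lower number from compound 2 to compound 3 (0.49 log units; beyond the scatter), both modest yet beyond the scatter. Read in reverse, they show the number rising in both cases when cyclopentyl gives way to an aromatic group. Benzyl also brings an aromatic ring, but no measured compound carries benzyl, so these steps are only a loose guide. The step expected in this assay is therefore a modest rise, a 2.5-fold higher number from compound 3 to compound 4 (0.40 log units; beyond the scatter). For compound 4 the estimate is 30 nM, with an expected range from 10 nM to 100 nM.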

Compound 4, half-maximal inhibitory concentration: > 1000 nM
Compound 4: a limit, no number; the forecaster's own chance of this, stated with the estimate: 2%; middle value at least 33-fold (1.52 log units) away from the limit.
By their numbers in this assay, from the lowest: compound 3; then compound 2; then compound 1. At a limit, above all of these: compound 4.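

Compound 4 gives only a limit, not a number, in this assay: the limit of > 1000 nM in this assay, at which 1 of the 4 values shown sits. Against that limit, the change from cyclopentyl to benzyl on this saturated ring carbon is large, an at least 83-fold higher number from compound 3 to compound 4 (1.92 log units; beyond the scatter), and the comparisons with the two aromatic groups are large as well, an at least 27-fold higher number from compound 2 to compound 4 (1.43 log units; beyond the scatter) and an at least 12-fold higher number from compound 1 to compound 4 (1.08 log units; beyond the scatter). The earlier compounds showed only modest differences among thiophen-2-yl, pyridin-4-yl and cyclopentyl, whereas benzyl shows that this position is far less forgiving than those three suggested, and the presence of an aromatic ring alone does not explain the loss, since compound 1 and compound 2 also carry one and still give measured values.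

The compounds shown leave open whether the sharp rise belongs to benzyl specifically or extends to close relatives such as phenyl or phenethyl. They also do not show how a simple open chain such as n-butyl, a larger saturated ring such as cyclohexyl, or a benzyl ring bearing a methoxy group or an amine would behave at this same position.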